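The source may report more compounds than this note shows. Statements on the series, on what has been measured and on what is new or still open speak of the compounds shown alone.

Compound 1 `Cc1ccc(SCc2ccc(/C=C/C(=O)Nc3ccccc3N)cc2)cc1` has the lowest value of the three measured compounds in a functional assay on HeLa cells (Homo sapiens) for inhibition, read by CCK-8 assay, with a stated time of 72 h, tested at 8 uM (a lower number here means less inhibition of growth, a higher number more inhibition of growth at the concentration tested), where compound 1 gives 21.7%. Compound 2 `Nc1ccccc1NC(=O)c1ccc(CSc2cccc(F)c2)cc1` gives 78.4% in this assay, and compound 3 `Cc1cc(C)cc(SCc2ccc(C(=O)Nc3ccccc3N)cc2)c1` gives 78.9%; neither of these two is linked to compound 1 by a change in a single place, so their much higher numbers cannot be traced to one feature. Among the compounds with values here, the only step between measured compounds, a number 0.5 percentage points higher from compound 2 to compound 3 (within the scatter), exchanges the phenyl on the sulfur and stays within the scatter. Compound 4 `CCc1ccc(SCc2ccc(/C=C/C(=O)Nc3ccccc3N)cc2)cc1` differs from compound 1 by methyl in place of hydrogen on a saturated chain carbon bound to an aromatic carbon. Within the data shown here, this change also sits on the phenyl on the sulfur, and the one comparable step between measured compounds did not move the number beyond the scatter. No step beyond the scatter is therefore expected, and the expected step is a number 3.3 percentage points higher from compound 1 to compound 4 (within the scatter). Compound 4 is estimated to give 25% in this assay, with a range from 10% to 45%.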

Compound 4, percent growth inhibition at one concentration: 20.9%
Estimate against measurement, compound 4: 4.1 percentage points above, and the stated range covers the measured number.
By their numbers in this assay, from the lowest: compounds 4 and 1 (each within the scatter of the next); then compounds 2 and 3 (each within the scatter of the next).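

In this assay the change from 4-methylphenyl to 4-ethylphenyl on the sulfur gives a number 0.8 percentage points lower from compound 1 to compound 4 (within the scatter), so adding a methyl on a saturated chain carbon bound to an aromatic carbon does not shift the result. Within the data shown here, until now, the only step on the phenyl on the sulfur joined compound 2 and compound 3, which share a different core and gave much higher numbers; this step shows that a change on that phenyl also stays within the scatter on the core of compound 1. No measurement shown here explains this flat result.

On these data alone, whether an amine, a carboxylic acid or a longer chain such as propyl at this place would shift the number remains open. Among these compounds, also open is what separates compound 1 from compound 2 and compound 3, as no step in a single place links them.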